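The source may report more compounds than this note shows. Statements on the series, on what has been measured and on what is new or still open speak of the compounds shown alone.

In a functional assay on HUVEC cells (Homo sapiens) for inhibition, with stated times of 2 h and 72 h (on this read-out lower numbers stand for stronger inhibition and higher numbers for weaker inhibition), compound 1 `COc1cc2nccc(Oc3ccc4c(NC(=O)Nc5ccc(C(F)(F)F)cc5Cl)nn(C)c4c3)c2cc1OC` reaches only the limit of the assay, > 1000 nM, so no number is known for it. Compound 2 `COc1cccc(Nc2nn(C)c3cc(Oc4ccnc5cc(OC)c(OC)cc45)ccc23)c1` likewise stops at a limit, > 1000 nM. Both values thus sit at the limit of > 1000 nM in this assay, at which 2 of the 2 values shown sit, and neither compound can be placed above or below the other. Compound 3 `COc1cc2nccc(Oc3ccc4c(NC(=O)Nc5ccc(C)cc5)nn(C)c4c3)c2cc1OC` has not yet been tested in this assay. It differs from compound 2 in one place: (4-methylphenyl)carbamoyl in place of 3-methoxyphenyl on a nitrogen on an aromatic ring. Compound 1 already carries a related carbamoyl group on a nitrogen on an aromatic ring and still gives only the limit > 1000 nM in this assay. The expected step is therefore a step that the limit leaves unreadable from compound 2 to compound 3, a change no larger than the scatter. Compound 3 is expected to give about 2000 nM in this assay, somewhere from 500 nM to 10000 nM, with a fair chance of another limit rather than a number.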

Compound 3, half-maximal inhibitory concentration: > 1000 nM
Compound 3 ended at the assay's limit (the forecaster's own chance of this, stated with the estimate: 70%); the middle value does not contradict the limit.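

Within the data shown here, compound 1, compound 2 and compound 3 all stop at the same limit, so no step between them can be read: the limit of > 1000 nM in this assay, at which 3 of the 3 values shown sit.

The compounds shown leave open how strongly each one inhibits in this assay and whether any change among them shifts that strength.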